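From pyrrolidin-1-yl to piperidin-1-yl on a shared core

The source may hold more compounds than are shown below. What is called first, only, known or untested is meant among the compounds shown, and "the series" means these compounds.

In a functional assay on L1210 cells (Mus musculus) for antiproliferative activity, read by cell counting, with a stated time of 2 days (a lower number here means a stronger inhibitor, a higher number a weaker inhibitor), compound 1 `COc1cc(C(=O)c2sc(N)nc2N)cc(OC)c1OC` gives 48000 nM. For the measured compounds named here, compound 2 `COc1cc(C(=O)c2sc(N3CCCC3)nc2N)cc(OC)c1OC` gives 370 nM, the lower of the two numbers so far, which makes it the stronger inhibitor of this pair. Going by the values given here, the only measured step, a 130-fold lower number from compound 1 to compound 2 (2.11 log units; beyond the scatter), is large and lies beyond the scatter. It comes with pyrrolidin-1-yl in place of amino on an aromatic carbon.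

Compound 3 `COc1cc(C(=O)c2sc(N3CCCCC3)nc2N)cc(OC)c1OC` keeps the shared core and changes that same carbon again, with piperidin-1-yl in place of pyrrolidin-1-yl on an aromatic carbon. Its value has not yet been measured. The measured step, a 130-fold lower number from compound 1 to compound 2 (2.11 log units; beyond the scatter), shows that the group on this carbon can move the number a long way, but it compares amino with a ring, not one ring with another. Among the compounds with values here, no measured pair compares two such rings, so the guide is weak. A far smaller change is expected here, somewhat more likely towards a higher number than a lower one. The expected step is a 1.9-fold higher number from compound 2 to compound 3 (0.28 log units; within the scatter). The estimate for compound 3 is 700 nM, with an expected range from 200 nM to 3000 nM.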

Compound 3, half-maximal inhibitory concentration: 43000 nM
Compound 3: the middle estimate sits 61-fold (1.79 log units) below what was measured; the whole stated range lies below it.
By their numbers in this assay, from the lowest: compound 2; then compounds 3 and 1 (each within the scatter of the next).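

In this assay the group on this carbon turns out to matter beyond simply being a ring: the six-membered piperidin-1-yl in place of the five-membered pyrrolidin-1-yl gives a 120-fold higher number from compound 2 to compound 3 (2.07 log units; beyond the scatter) and so cancels the whole of the earlier large step. Set against amino, piperidin-1-yl gives a 1.1-fold lower number from compound 1 to compound 3 (0.05 log units; within the scatter) and this lies within the scatter, so of the three groups seen on this carbon only pyrrolidin-1-yl stands apart, with compound 2 beyond the scatter of both compound 1 and compound 3. Nothing available accounts for this sharp difference between two such similar rings.

The compounds shown leave open whether the effect follows ring size as such, and how a four-membered azetidin-1-yl, a seven-membered azepan-1-yl, a morpholin-4-yl or an open-chain dimethylamino group would stand on the same carbon. They also leave open whether pyrrolidin-1-yl would keep its place among these groups if the amino group or the trimethoxybenzoyl part of the shared core were changed.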